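The source may report more compounds than this note shows. Statements on the series, on what has been measured and on what is new or still open speak of the compounds shown alone.

Three compounds share one scaffold: compound 1 `Cc1cc(N2CCC(N3CCCC3C)C2)ccc1NC(=O)C1CCOCC1`, compound 3 `Cc1cc(N2CCC(N3CCCC3C)C2)ccc1NC(=O)C1CC2CCC1C2` and compound 2 `Cc1cc(NC(=O)C2CC3CCC2C3)ccc1N1CCC(N2CCCC2C)C1`. In an assay on CHO cells for displacement of a labelled ligand from histamine receptor H3 (Macaca mulatta) (on this read-out lower numbers stand for stronger inhibition and higher numbers for weaker inhibition), compound 1 gives 6.8 nM, compound 3 gives 19.9 nM and compound 2 gives 130 nM. Compound 1 differs from compound 3 by a group of 6 heavy atoms (5 carbon, 1 oxygen; one six-membered non-aromatic ring with 1 hetero atom) in place of a group of 7 heavy atoms (7 carbon; 2 five-membered non-aromatic rings of carbon only), on a carbonyl carbon, a change that brought a 2.9-fold lower number from compound 3 to compound 1 (0.47 log units; beyond the scatter). Compound 4 `Cc1cc(NC(=O)C2CCOCC2)ccc1N1CCC(N2CCCC2C)C1` has not yet been measured; it differs from compound 2 by a group of 6 heavy atoms (5 carbon, 1 oxygen; one six-membered non-aromatic ring with 1 hetero atom) in place of a group of 7 heavy atoms (7 carbon; 2 five-membered non-aromatic rings of carbon only), on a carbonyl carbon, the same change at the same place, on a core whose difference from the core of compound 3 is not broken down here. Because the earlier step was a 2.9-fold lower number from compound 3 to compound 1 (0.47 log units; beyond the scatter), a step of similar size is expected, a 2.9-fold lower number from compound 2 to compound 4 (0.46 log units; beyond the scatter), though one earlier case is a thin basis. Compound 4 is estimated at 45 nM in this assay, between 18 nM and 110 nM.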

Compound 4, inhibition constant: 17 nM
Beside the measured number, compound 4's estimate is 2.6-fold (0.42 log units) above it; the measured number lies below the stated range.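

Replacing the all-carbon group with two five-membered rings by oxan-4-yl on the carbonyl carbon lowered the number again in this assay, with a 7.6-fold lower number from compound 2 to compound 4 (0.88 log units; beyond the scatter). The direction held on both cores, and the two steps do not differ in size by more than repeated measurements would allow: the same change on two cores in this assay, a 2.9-fold lower number (0.47 log units; beyond the scatter) from compound 3 to compound 1 and a 7.6-fold lower number (0.88 log units; beyond the scatter) from compound 2 to compound 4, 2.6-fold (0.42 log units) apart, within the scatter of two such steps. This shows that the change carried over between these two cores, but two pairs cannot show that it would hold on other cores, and they do not explain why the number falls.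

The compounds shown leave open whether the ring oxygen of oxan-4-yl matters, which cyclohexyl on the same carbonyl carbon could test. On these data alone, a piperidine ring there is equally open.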